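Replacing a carbamoyl with a heteroaromatic ring: expected solubility

The source may hold more compounds than are shown below. What is called first, only, known or untested is meant among the compounds shown, and "the series" means these compounds.

Measured compounds:
- compound 1, `CC(C)C(/C=C1\CCNC1=O)c1ccc(-c2ccc3cccc(F)c3c2)[nH]c1=O`, with 20700 nM
- compound 2, `CC(C)C(c1ccc(-c2ccc3cccc(F)c3c2)[nH]c1=O)N1CCN/C1=N\C#N`, with 25200 nM
- compound 3, `CC(C)C(CC(N)=O)c1ccc(-c2ccc3cccc(F)c3c2)[nH]c1=O`, with 5600 nM

All three share the same core and were measured in a physicochemical assay for solubility, in phosphate buffer, measured as kinetic solubility; a higher number here means a more soluble compound, a lower number a less soluble compound. Compound 3 stands lowest of the three: compound 1 is nearer, and compound 2 is furthest, both beyond the scatter, while compound 1 and compound 2 lie within the scatter of each other (a 1.2-fold higher number from compound 1 to compound 2 (0.09 log units; within the scatter)).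

Compound 4, `CC(C)C(Cc1noc(=O)[nH]1)c1ccc(-c2ccc3cccc(F)c3c2)[nH]c1=O`, is not yet measured. It differs from compound 3 by a group of 6 heavy atoms (2 carbon, 2 nitrogen, 2 oxygen; one five-membered aromatic ring with 3 hetero atoms) in place of a group of 3 heavy atoms (1 carbon, 1 nitrogen, 1 oxygen; no ring), on a saturated chain carbon, two bonds along the chain from an aromatic carbon. Among the measured compounds shown here, the steps that bear on this are the ones leading into compound 3: a 3.7-fold lower number from compound 1 to compound 3 (0.57 log units; beyond the scatter) and a 4.5-fold lower number from compound 2 to compound 3 (0.65 log units; beyond the scatter). In both, a larger ring-bearing group was exchanged for the small carbamoyl and the number fell modestly. The change to compound 4 runs the other way, putting a ring-bearing group of 6 heavy atoms in place of the carbamoyl, so a modest rise is expected, of a size similar to those two steps: a 2.7-fold higher number from compound 3 to compound 4 (0.43 log units; beyond the scatter). Compound 4 is therefore estimated at 15000 nM, with a range from 5000 nM to 40000 nM.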

Compound 4, solubility: 30400 nM
Compound 4: the middle estimate sits 2.0-fold (0.31 log units) below what was measured; the range from low to high includes it.
By their numbers in this assay, from the lowest: compound 3; then compounds 1, 2 and 4 (each within the scatter of the next).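

In this assay, a 5.4-fold higher number from compound 3 to compound 4 (0.73 log units; beyond the scatter) is the first step shown at this place, on a saturated chain carbon, two bonds along the chain from an aromatic carbon, and it shows that the number there changes with the group attached. Compound 4 also carries an aromatic ring where compounds 1 and 2 carry non-aromatic ones, yet a 1.2-fold higher number from compound 2 to compound 4 (0.08 log units; within the scatter) and a 1.5-fold higher number from compound 1 to compound 4 (0.17 log units; within the scatter) are both printed as within the scatter, so the three ring-bearing compounds stand together and only the carbamoyl compound, compound 3, stands apart. Nothing among the data shown accounts for this change.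

Still open, on these data alone, is how a carboxylic acid or an amine would read at this place. A longer chain carrying the same five-membered aromatic ring is also untested among the compounds shown here.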